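Mirror Image of a Cyclohexyl Amide: Compound 3

A few compounds are considered here, and "the series" means these few. Any claim that something is new, unique, unknown or untested is made for them only; others in the source may bear on it.

Measured so far:
- Compound 1 `CN(CCCc1ccccc1)C(=O)c1ccc[nH]1` gives 8900 nM in an assay on mitochondria for inhibition of Amine oxidase [flavin-containing] B (Bos taurus), read by fluorescence; on this read-out lower numbers stand for stronger inhibition and higher numbers for weaker inhibition
- Compound 2 `C[C@H](C1CCCCC1)N(C)C(=O)c1ccc[nH]1` gives 30 nM in this assay

Of the two compounds measured in this assay, compound 2 has the lower number, and the gap to compound 1 lies well beyond the usual scatter of repeated measurements, so compound 2 stands clearly apart as the stronger of the pair.

The next compound keeps everything in place. Compound 3 `C[C@@H](C1CCCCC1)N(C)C(=O)c1ccc[nH]1` differs from compound 2 only in this respect: the two compounds have the same atoms and bonds and differ only in configuration as drawn: 1 of 1 stereo elements differ; a stereocentre at a saturated chain carbon is drawn R in compound 2 and S in compound 3. In words, the two compounds have the same atoms and bonds and differ only in configuration as drawn; a stereocentre at a saturated chain carbon is drawn R in compound 2 and S in compound 3.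

For the measured compounds named here, no measured pair here shows what such a change in configuration does in this assay. A mirror-image arrangement at the one stereocentre is commonly expected to weaken binding rather than leave it unchanged, so a step from compound 2 to compound 3 that goes beyond the scatter toward a higher number is expected. For compound 3 a value of 300 nM is estimated, within a range of 40 nM to 3000 nM, which corresponds to an expected step of a 10-fold higher number from compound 2 to compound 3 (1.00 log units; beyond the scatter).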

Compound 3, inhibition constant: 4100 nM
The estimate for compound 3 lay 14-fold (1.14 log units) below the measured number; the whole stated range lies below it.
By their numbers in this assay, from the lowest: compound 2; then compound 3; then compound 1.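

In this assay, turning the one stereocentre at the saturated chain carbon into its mirror image, from R to S as drawn, gives a 140-fold higher number from compound 2 to compound 3 (2.14 log units; beyond the scatter) and so counts as a large change. Compounds 1 and 2 differ in more than one place and could not show what any single feature is worth, whereas this pair isolates one feature and shows that the spatial arrangement at this carbon, with the atoms and bonds left untouched, matters greatly in this assay. The whole step can be assigned to that arrangement, because nothing else separates the two compounds: the fact that compounds 2 and 3 differ only in the configuration as drawn

The pair shows only how much the configuration matters, not how the R form achieves its lower number, since nothing here describes how either compound binds. It also leaves open whether the R form would keep its advantage if an ethyl group, a longer chain or an amine were carried at this carbon, or if the cyclohexyl group gave way to another group.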